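Fluoro to chloro at the edge of the assay limit

The compounds below may be only part of what the source reports. "The series", "measured", "known", "first", "only" and "open" are said of these compounds alone.

The three measured compounds, with their readings in an ADME assay on L02 cells (Homo sapiens) for antiproliferative activity, read by MTT assay, with a stated time of 48 h; on this read-out lower numbers stand for stronger inhibition and higher numbers for weaker inhibition:

Compound 1 `Cc1cccc(-n2nncc2CN2C(=O)C3(C(C#N)=C(N)Oc4c(N)cc5nc6ccccc6nc5c43)c3ccccc32)c1` gives > 50000 nM, which is a limit of the assay rather than a number.
Compound 2 `CCc1ccccc1-n1nncc1CN1C(=O)C2(C(C#N)=C(N)Oc3c(N)cc4nc5ccccc5nc4c32)c2ccccc21` gives 22900 nM.
Compound 3 `N#CC1=C(N)Oc2c(N)cc3nc4ccccc4nc3c2C12C(=O)N(Cc1cnnn1-c1ccc(F)cc1)c1ccccc12` gives > 50000 nM, again a limit and not a number.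

Compound 3 therefore stands at the weak end of what was seen, and it is not alone there: the limit of > 50000 nM in this assay, at which 2 of the 3 values shown sit. Among the measured steps, an at least 2.1-fold lower number from compound 1 to compound 2 (0.33 log units; beyond the scatter), an at least 2.1-fold higher number from compound 2 to compound 3 (0.33 log units; beyond the scatter), and a step that the two limits leave unreadable from compound 1 to compound 3. Each of these steps exchanges one whole aryl group on the triazole nitrogen for another.

Compound 4 `N#CC1=C(N)Oc2c(N)cc3nc4ccccc4nc3c2C12C(=O)N(Cc1cnnn1-c1ccc(Cl)cc1)c1ccccc12` differs from compound 3 by a smaller move: chloro in place of fluoro on an aromatic carbon. No measured step makes this same exchange, so nothing shown points to a clear shift in either direction. The nearest anchor is compound 3 itself, which sits at the limit with > 50000 nM. Compound 4 is accordingly expected to give about 45000 nM, somewhere between 18000 nM and 120000 nM, and may well again be reported only as a limit. That expectation amounts to an at least 1.1-fold lower number from compound 3 to compound 4 (0.04 log units; that floor lies within the scatter).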

Compound 4, half-maximal inhibitory concentration: > 50000 nM
Compound 4: no number, only a limit; the forecaster's own chance of this, stated with the estimate: 60%; at least 1.1-fold (0.04 log units) between middle value and limit.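

Exchanging fluoro for chloro on this ring does not lift the reading off the limit, so in this assay neither halogen gives a number at this place. Going by these compounds alone, the one readable comparison is with the 2-ethylphenyl group, and exchanging it for 4-chlorophenyl gives an at least 2.1-fold higher number from compound 2 to compound 4 (0.33 log units; beyond the scatter), so chloro, like fluoro, does not match the measurable inhibition of compound 2. The steps among compound 1, compound 3 and compound 4 cannot be read, since each joins two limits, and the readings now gather at one end: the limit of > 50000 nM in this assay, at which 3 of the 4 values shown sit.

From the compounds shown here alone, whether compound 3 and compound 4 differ at all stays open, with neither giving a number. Also open, going by these compounds, is whether an amine in place of the halogen, or a propyl chain in place of the ethyl of compound 2, would give a reading clear of the limit.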